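The source may report more compounds than this note shows. Statements on the series, on what has been measured and on what is new or still open speak of the compounds shown alone.

In a functional assay on MDA-MB-231 cells (Homo sapiens) for inhibition, read by MTT assay, with a stated time of 72 h (a lower number here means a stronger inhibitor, a higher number a weaker inhibitor), two compounds have been tested so far. Compound 1 `Cc1ccc(NC(=S)CCCn2cc(-c3ccc(C(F)(F)F)cc3)nn2)cc1` gives 83200 nM. Compound 2 `COC(=O)c1ccc(-c2cn(CCCC(=S)Nc3ccc(-c4ccccc4)cc3)nn2)cc1` stands at > 100000 nM, which is a limit of this assay and not a number. Compound 3 `FC(F)(F)c1ccc(-c2cn(CCCC(=S)Nc3ccc(-c4ccccc4)cc3)nn2)cc1` differs from compound 2 in one place: trifluoromethyl in place of methoxycarbonyl on an aromatic carbon. In words, trifluoromethyl takes the place of methoxycarbonyl on an aromatic carbon, para to a large group. For the measured compounds named here, no measured pair of compounds shows this change on its own, so the expectation rests on thin ground. Going by the values given here, the only guide is compound 1, which also carries the 4-(trifluoromethyl)phenyl group and gives 83200 nM. A small step towards stronger inhibition is therefore expected, and the expected step of an at least 1.5-fold lower number from compound 2 to compound 3 (0.18 log units; that floor lies within the scatter) may not clear the usual scatter. For compound 3 the estimate is 65000 nM, with an expected range from 22000 nM to 100000 nM.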

Compound 3, half-maximal inhibitory concentration: > 100000 nM
Compound 3: no number, only a limit (the forecaster's own chance of this, stated with the estimate: 40%); at least 1.5-fold (0.18 log units) between middle value and limit.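

In this assay, compound 3 gives a limit and not a number, so trifluoromethyl in place of methoxycarbonyl on this aromatic carbon, para to a large group, yields no readable step from compound 2, because both compounds sit at the same limit: the limit of > 100000 nM in this assay, at which 2 of the 3 values shown sit. The 4-(trifluoromethyl)phenyl group of compound 1 therefore does not bring a number within reach when it is carried by compound 3. For the compounds shown here, the only readable step is an at least 1.2-fold higher number from compound 1 to compound 3 (0.07 log units; that floor lies within the scatter), with phenyl in place of methyl on an aromatic carbon, and it does not establish a real loss of strength.

Which of trifluoromethyl and methoxycarbonyl does better at this position remains unknown. Also open, as far as these compounds go, is whether an amine or a carboxylic acid on this aromatic carbon, or a longer chain, would give a value that this assay can read as a number.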